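Swapping one phenyl group: from compound 2 to compound 3

The compounds below may be only part of what the source reports. "The series", "measured", "known", "first", "only" and "open" are said of these compounds alone.

In an ADME assay on KB cells (Homo sapiens) for cytotoxicity, read by MTT assay, with a stated time of 72 h (on this read-out lower numbers stand for stronger inhibition and higher numbers for weaker inhibition), compound 1 (`COc1cc(C2=C(c3cc(C)c(OC)c(C)c3)C(O)CC2=O)cc(OC)c1OC`) reads > 100 ug/mL and this is a limit of the assay, not a number. Among the compounds with values here, compound 2 (`COCOc1cc(C2=C(c3cc(OC)c(OC)c(OC)c3)C(=O)CC2O[SiH2]C(C)(C)C)ccc1OC`) gives 33 ug/mL in this assay and holds the only actual number so far. Compound 3 (`COc1cc(C2=C(c3cc(C)c(OC)c(C)c3)C(O[SiH2]C(C)(C)C)CC2=O)cc(OC)c1OC`) has yet to be measured. It differs from compound 2 at one place, on a double-bonded ring carbon, where 4-methoxy-3,5-dimethylphenyl stands in place of 4-methoxy-3-(methoxymethoxy)phenyl (4-methoxy-3,5-dimethylphenyl in place of 4-methoxy-3-(methoxymethoxy)phenyl on a double-bonded ring carbon). Within the data shown here, no measured pair shows what such a swap does, so the expectation starts from compound 2 at 33 ug/mL and allows for no shift beyond the scatter, with a slight lean towards weaker inhibition. The estimated step is a 1.2-fold higher number from compound 2 to compound 3 (0.08 log units; within the scatter) and so stays small. For compound 3 the expected value is 40 ug/mL with 13 ug/mL to 100 ug/mL as the expected range.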

Compound 3, half-maximal inhibitory concentration: 40 ug/mL
Compound 3: middle estimate and measured number agree at the digits printed, within the range that was stated.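

Putting 4-methoxy-3,5-dimethylphenyl in place of 4-methoxy-3-(methoxymethoxy)phenyl on the double-bonded ring carbon gives a 1.2-fold higher number from compound 2 to compound 3 (0.08 log units; within the scatter), so this assay does not tell these two groups apart. Placing a group of 5 heavy atoms (4 carbon, 1 silicon; no ring) instead of a hydrogen atom, on an oxygen on a saturated carbon, gives an at least 2.5-fold lower number from compound 1 to compound 3 (0.39 log units; beyond the scatter), the only step here beyond the scatter. The true size of that step stays unknown because compound 1 stands at a limit of the assay rather than at a number: the limit of > 100 ug/mL in this assay, at which 1 of the 3 values shown sits.

Going by these compounds, whether the same change on that oxygen would act alike alongside 4-methoxy-3-(methoxymethoxy)phenyl remains open. Also open, on these data alone, is what an amine or a carboxylic acid on the swapped phenyl group, or a longer carbon chain on that oxygen, would do to the read-out.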